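Swapping Chloro for Fluoro on a Second Core

The source may report more compounds than this note shows. Statements on the series, on what has been measured and on what is new or still open speak of the compounds shown alone.

Compound 1 `CC(=O)OC/C(=C\c1ccc(Cl)cc1)C(=O)c1ccccc1` and compound 2 `CC(=O)OC/C(=C\c1ccc(F)cc1)C(=O)c1ccccc1` share one core and differ in a single place. Compound 3 `C=C(C/C(=C\c1ccc(Cl)cc1)C(=O)c1ccccc1)C(=O)c1ccccc1` and the not yet measured compound 4 `C=C(C/C(=C\c1ccc(F)cc1)C(=O)c1ccccc1)C(=O)c1ccccc1` share a second core; how this core differs from the core of compound 1 is not broken down here. In a functional assay on T47D cells (Homo sapiens) for inhibition, read by sulforhodamine B assay, with a stated time of 48 h (a lower number here means a stronger inhibitor of growth, a higher number a weaker inhibitor of growth), compound 1 gives 5300 nM, and compound 2 gives 14000 nM. The change between them, (fluoro in place of chloro on an aromatic carbon), made a step of a 2.6-fold higher number from compound 1 to compound 2 (0.42 log units; beyond the scatter). In this assay compound 3 gives 19000 nM; against compound 2 this lies within the scatter, while against compound 1 it is the higher number. Compound 4 carries the same change as compound 2, (fluoro in place of chloro on an aromatic carbon), now on the second core. Among the compounds with values here, that earlier step is the only measured example of this change, so the expectation for compound 4 rests on it alone, and a step of similar size is expected, a 2.1-fold higher number from compound 3 to compound 4 (0.32 log units; beyond the scatter). Compound 4 is therefore estimated to give 40000 nM in this assay, likely between 15000 nM and 110000 nM.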

Compound 4, concentration for 50% growth inhibition: 15000 nM
Beside the measured number, compound 4's estimate is 2.7-fold (0.43 log units) above it; the measured number falls inside the stated range.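

In this assay, putting fluoro in place of chloro on the second core gives a 1.3-fold lower number from compound 3 to compound 4 (0.10 log units; within the scatter), a step too small to tell apart from the ordinary spread of repeat measurements. On the first core the same change gave a real loss of growth inhibition, so its size did not carry over, and the two steps differ by more than scatter can explain: the same change on two cores in this assay, a 2.6-fold higher number (0.42 log units; beyond the scatter) from compound 1 to compound 2 and a 1.3-fold lower number (0.10 log units; within the scatter) from compound 3 to compound 4, 3.3-fold (0.52 log units) apart, beyond the scatter of two such steps

Within the data shown here, this shows that, in this series, the step measured on one core was a poor guide to the step on the other, but with only one pair on each core it does not show why the cores behave differently or which of the two steps is more typical.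

The compounds shown carry only chloro or fluoro at this place, so it stays open whether bromo, methoxy or an amine there would show a clear step on either core. From the compounds shown here alone, it also stays open whether a third core would follow the first or the second.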